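A few compounds are considered here, and "the series" means these few. Any claim that something is new, unique, unknown or untested is made for them only; others in the source may bear on it.

Three measured compounds share one core and are compared in a single test. Compound 1 `Nc1nc(NCc2cccs2)nc2sc(-c3cccs3)nc12` gives 547 nM in a functional assay on CHO cells for agonist activity at adenosine receptor A2b (Homo sapiens), read by scintillation counting and cAMP accumulation, with a stated time of 150 min, in the presence of a further agent that is not named here; a lower number here means a stronger inhibitor, a higher number a weaker inhibitor. Compound 2 `COc1ccccc1CNc1nc(N)c2nc(-c3cccs3)sc2n1` gives 4570 nM in this assay, the highest of the three numbers, while compound 3 `Nc1nc(NCc2ccsc2)nc2sc(-c3ccco3)nc12` gives 8.96 nM. Among the measured compounds shown here, the only step between direct neighbours, an 8.4-fold higher number from compound 1 to compound 2 (0.92 log units; beyond the scatter), concerns the group on a saturated chain carbon bound to a nitrogen on an aromatic ring, not the group on the core. Compound 4 `COc1ccccc1CNc1nc(N)c2nc(-c3ccc(C)o3)sc2n1` differs from compound 2 at that other place: 5-methylfuran-2-yl in place of thiophen-2-yl on an aromatic carbon. For the measured compounds named here, no measured step bears directly on this exchange. Compounds 1 and 3 carry thiophen-2-yl and furan-2-yl on that aromatic carbon, but they also differ on the chain, so it can only be noted that compound 1 gives 547 nM and compound 3 gives 8.96 nM, the furan-bearing one sitting far lower. Compound 4 is therefore expected to come in lower than compound 2, by a 3.8-fold lower number from compound 2 to compound 4 (0.58 log units; beyond the scatter), with wide uncertainty. Compound 4 is estimated at 1200 nM, between 250 nM and 6000 nM.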

Compound 4, half-maximal inhibitory concentration: 389 nM
Beside the measured number, compound 4's estimate is 3.1-fold (0.49 log units) above it; low and high end bracket the measured number.
By their numbers in this assay, from the lowest: compound 3; then compounds 4 and 1 (each within the scatter of the next); then compound 2.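

Exchanging thiophen-2-yl for 5-methylfuran-2-yl on the aromatic carbon gives a 12-fold lower number from compound 2 to compound 4 (1.07 log units; beyond the scatter) in this assay, with the 2-methoxyphenyl group on the chain left unchanged. Among the compounds shown here, this is the first direct reading of that position: compound 1 and compound 3 differ in two places, so they could not separate the group on the core from the group on the chain, whereas this step shows that the core position alone can move the number beyond the scatter. The data shown offer no measurement that explains the shift.

The exchange replaces the ring sulfur with a ring oxygen and also adds a methyl group, so the compounds shown cannot tell which of the two matters; 5-methylthiophen-2-yl, or furan-2-yl on this same chain, would separate them. Going by these compounds, how a phenyl ring or an amine on that carbon would read in this assay also remains open.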